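The source may hold more compounds than are shown below. What is called first, only, known or untested is meant among the compounds shown, and "the series" means these compounds.

Measured compounds:
compound 1 `CCCn1c(=O)[nH]c2nc(-c3ccc(S(=O)(=O)N4CCN(c5ccc(Br)cc5)CC4)cc3)[nH]c2c1=O`: 13%
compound 2 `CCCn1c(=O)[nH]c2nc(-c3ccc(S(=O)(=O)N4CCN(c5ccccc5F)CC4)cc3)[nH]c2c1=O`: 13%

In an assay on CHO cells for displacement of a labelled ligand from adenosine receptor A1 (Homo sapiens), read by scintillation counting, with a stated time of 90 min, tested at 1 uM, in the presence of a further agent that is not named here (a lower number here means less inhibition, a higher number more inhibition at the concentration tested (going by the name of the read-out)), compound 1 gives 13%. Compound 2 gives 13% in this assay, and the step of no change at the digits printed from compound 1 to compound 2 (within the scatter) shows that swapping the group on the ring nitrogen between these two compounds left the read-out where it was. Compound 2 thus stands level with compound 1, with no order between them that the scatter would support.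

Compound 3 `CCCn1c(=O)[nH]c2nc(-c3ccc(S(=O)(=O)N4CCN(Cc5ccc(Br)cc5)CC4)cc3)[nH]c2c1=O` differs from compound 2 by 4-bromobenzyl in place of 2-fluorophenyl on an amine nitrogen in a ring. Going by the values given here, the single measured step, from compound 1 to compound 2, is the only one that bears on this change, and it concerns a swap of one aromatic ring for another on the same ring nitrogen; it was within the scatter. Among the compounds with values here, no measured step covers the entering 4-bromobenzyl group, so the estimate rests on the observation that the group on that nitrogen has so far not moved the number. Compound 3 is therefore expected to show a step of no change at the digits printed from compound 2 to compound 3 (within the scatter), none beyond the scatter. Compound 3 is estimated at 13%, with a range from 0% to 32%.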

Compound 3, a percentage reported as inhibition, at one concentration (the size of the read-out at that concentration, not a potency): 31%
Estimate against measurement, compound 3: 18 percentage points below; the measured number falls inside the stated range.
By their numbers in this assay, from the lowest: compounds 1 and 2 (each within the scatter of the next); then compound 3.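

In this assay the group on the amine nitrogen in the ring can move the number after all: the change to 4-bromobenzyl gives a number 18 percentage points higher from compound 2 to compound 3 (beyond the scatter) and so sets compound 3 apart from the two earlier compounds. The cleaner comparison keeps the 4-bromo ring and puts a benzyl group in place of a phenyl group, which gives a number 18 percentage points higher from compound 1 to compound 3 (beyond the scatter) even though the exchange of one aromatic ring for another on that nitrogen had given no change at the digits printed from compound 1 to compound 2 (within the scatter) and so had shown no sensitivity at this position. Among these three compounds, then, the one carrying the benzyl group stands apart from the two carrying a phenyl group, though no measurement at hand accounts for the rise.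

How an unsubstituted benzyl or a 2-fluorobenzyl group would read on that nitrogen remains open, so the compounds shown do not tell whether the benzyl group alone is enough or whether the bromine also plays a part. Also open, on these data alone, is whether a longer chain, such as 2-phenylethyl, or a benzoyl group on the same nitrogen would raise the number further or lose the gain.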